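The compounds below may be only part of what the source reports. "The series", "measured", "known", "first", "only" and "open" are said of these compounds alone.

Series notes. Compound 1 `C=C(c1cc(Cl)cc(Cl)c1OCc1ccccc1)C1COC2(CCCC2)OO1`, compound 2 `C=C(c1ccc(Cl)c(Cl)c1)C1COC2(CCCC2)OO1` and compound 3 `C=C(c1ccc(Cl)c(Cl)c1Cl)C1COC2(CCCC2)OO1` share one core and differ only in the chloro pattern on the aromatic ring. In a functional assay on BEAS-2B cells (Homo sapiens) for inhibition, read by MTT assay, with a stated time of 72 h (on this read-out lower numbers stand for stronger inhibition and higher numbers for weaker inhibition), compound 1 gives 28600 nM, compound 2 gives 50900 nM and compound 3 gives 11500 nM. Compound 3 thus stands lowest of the three numbers, with compound 1 nearest and compound 2 furthest, both beyond the scatter. Going by the values given here, the only single-point step measured so far is a 4.4-fold lower number from compound 2 to compound 3 (0.65 log units; beyond the scatter), a chloro added on an aromatic carbon.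

Compound 4 `C=C(c1ccc(Cl)cc1Cl)C1COC2(CCCC2)OO1` is next. Relative to compound 3 the change is hydrogen in place of chloro on an aromatic carbon. Among the compounds with values here, the step from compound 2 to compound 3 is the only measured change of this kind and it runs the other way, so read in reverse it points to a higher number for compound 4 of roughly that size. The leaving chloro does not sit where the entering one sat in compound 2, so compound 2 is only a loose guide; compound 2 shows at 50900 nM where another dichloro pattern landed.

Compound 4 is therefore expected near 35000 nM, with a range of 12000 nM to 100000 nM. The expected step is a 3.0-fold higher number from compound 3 to compound 4 (0.48 log units; beyond the scatter), a modest rise beyond the scatter.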

Compound 4, half-maximal inhibitory concentration: 17400 nM
The estimate for compound 4 lay 2.0-fold (0.30 log units) above the measured number; low and high end bracket the measured number.
By their numbers in this assay, from the lowest: compounds 3, 4, 1 and 2 (each within the scatter of the next, the first and the last beyond it).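

In this assay the exchange gives a 1.5-fold higher number from compound 3 to compound 4 (0.18 log units; within the scatter) and so, in this pair, the chloro ortho to two chloro groups and meta to a large group can give way to hydrogen with no readable difference. The earlier 4.4-fold lower number from compound 2 to compound 3 (0.65 log units; beyond the scatter) involves a chloro at a different carbon of the same aromatic ring and lies beyond the scatter, so among these compounds the two chloro places do not count alike. No measurement at hand accounts for this contrast between the two places.

The compounds shown leave open whether another group at this carbon, such as a methoxy group, an amine or a carboxylic acid, would also stay within the scatter of compound 3 as hydrogen does. They also leave open whether the same tolerance would hold on the ring pattern of compound 1, which differs from compound 3 in more than one place and so offers no clean comparison.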